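This account rests on a few compounds, and the source may have more. Where it says the series, first, only, none or still open, it means among the compounds named here.

Working notes on a small set of isatin-type compounds tested in a functional assay on MDA-MB-231 cells (Homo sapiens) for cytotoxicity, read by sulforhodamine B assay, with a stated time of 48 h; on this read-out higher numbers stand for weaker inhibition of growth and lower numbers for stronger inhibition of growth. Compound 1 `O=C1C(=O)N(CN(c2ccccc2)c2ccccc2)c2ccccc21` gives 24800 nM in this assay. Compound 2 `CN(C)CN1C(=O)C(=O)c2c(Br)cccc21` gives 93700 nM. Compound 3 `CCN(CC)CN1C(=O)C(=O)c2c(Br)cccc21` gives 20200 nM. Among the compounds with values here, the one measured step that changes a single place is a 4.6-fold lower number from compound 2 to compound 3 (0.67 log units; beyond the scatter), the exchange of the amine on the chain carbon. On the numbers shown, compound 3 holds the lowest figure of the three; the gap to compound 1 is within the scatter, so the two cannot be ordered, while the gap to compound 2 is beyond the scatter.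

Compound 4 `CCN(CC)CN1C(=O)C(=O)c2c(Cl)cccc21` differs from compound 3 in one place: chloro in place of bromo on an aromatic carbon. Within the data shown here, none of the measured steps touches the halogen on the aromatic ring; the only measured step, a 4.6-fold lower number from compound 2 to compound 3 (0.67 log units; beyond the scatter), concerns the amine on the chain and does not bear on this change. With nothing in the measured data pointing either way, the expectation for this assay is a step that stays within the scatter, with no firm direction.

For compound 4 the estimated value in this assay is 25000 nM, with a range from 10000 nM to 60000 nM. The expected step of a 1.2-fold higher number from compound 3 to compound 4 (0.09 log units; within the scatter) is therefore within the scatter.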

Compound 4, concentration for 50% growth inhibition: 44500 nM
For compound 4 the middle estimate is 1.8-fold (0.25 log units) below the measured one; low and high end bracket the measured number.
By their numbers in this assay, from the lowest: compounds 3, 1 and 4 (each within the scatter of the next, the first and the last beyond it); then compound 2.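

In this assay the halogen on the aromatic carbon proves to be a place that registers: chloro in place of bromo gives a 2.2-fold higher number from compound 3 to compound 4 (0.34 log units; beyond the scatter), a modest step but one beyond the scatter, whereas the earlier single-place step concerned only the amine on the chain carbon. The series therefore now has two places where a single exchange moves the number, the second being a 4.6-fold lower number from compound 2 to compound 3 (0.67 log units; beyond the scatter), and in this pair the bromo compound holds the lower figure, although the finding rests on one pair with diethylamino on the chain. The measured data offer no explanation of why the two halogens differ.

From the compounds shown here alone, it remains open whether the same halogen exchange gives a step of like size and direction with dimethylamino on the chain, and how fluoro, iodo or methoxy on that aromatic carbon would compare with bromo and chloro. A ring amine such as morpholine or piperidine on the chain carbon, in place of diethylamino, is equally unresolved by the compounds shown.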